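This account rests on a few compounds, and the source may have more. Where it says the series, first, only, none or still open, it means among the compounds named here.

Measured to date in a functional assay on A549 cells (Homo sapiens) for cytotoxicity, read by MTT assay, with a stated time of 72 h; on this read-out lower numbers stand for stronger inhibition and higher numbers for weaker inhibition:
compound 1 `CC1CCN(Cc2ccc3nc(NC(=O)N/N=C/c4c[nH]c5ccccc45)sc3c2)CC1`: 3580 nM
compound 2 `CC1CCN(Cc2ccc3nc(NC(=O)N/N=C/c4cn(Cc5ccccc5)c5ccccc45)sc3c2)CC1`: 2340 nM

Compound 2 holds the lowest of the two numbers; its nearest neighbour is compound 1, separated by a 1.5-fold lower number from compound 1 to compound 2 (0.18 log units; within the scatter), so the two are not distinguishable. Compound 3 `CC1CCN(Cc2ccc3nc(NC(=O)N/N=C/c4cn(Cc5ccc(Cl)cc5)c5ccccc45)sc3c2)CC1` differs from compound 2 by chloro in place of hydrogen on an aromatic carbon. Within the data shown here, no measured step touches the benzyl ring, and the single step on record, a 1.5-fold lower number from compound 1 to compound 2 (0.18 log units; within the scatter), concerns a different place and stays within the scatter. No shift beyond the scatter is therefore expected in this assay; the step of a 1.2-fold lower number from compound 2 to compound 3 (0.09 log units; within the scatter) is the estimate. For compound 3 the expected value is 1900 nM, within 700 nM to 5000 nM.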

Compound 3, half-maximal inhibitory concentration: 2030 nM
Beside the measured number, compound 3's estimate is 1.1-fold (0.03 log units) below it; the range from low to high includes it.
By their numbers in this assay, from the lowest: compounds 3, 2 and 1 (each within the scatter of the next).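

Chloro is the first change on the benzyl ring itself, and in this assay the step, a 1.2-fold lower number from compound 2 to compound 3 (0.06 log units; within the scatter), leaves benzyl and 4-chlorobenzyl indistinguishable. Measured against hydrogen on the aromatic nitrogen, 4-chlorobenzyl also gives no readable shift, with a 1.8-fold lower number from compound 1 to compound 3 (0.25 log units; within the scatter). No supporting data bear on these results.

Still open, on these data alone, is whether a methoxy group, a nitrile or an amine at this ring position would move the number beyond the scatter. Also open, as far as these compounds go, is whether a longer chain in place of benzyl on the nitrogen would do so.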